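The source may report more compounds than this note shows. Statements on the series, on what has been measured and on what is new or still open speak of the compounds shown alone.

Compounds 1 to 3 share one core and differ at the end of an amide chain or on the aromatic ring attached to it. In a functional assay on HepG2 cells (Homo sapiens) for cytotoxicity, read by MTT assay, with a stated time of 72 h (a lower number here means a stronger inhibitor, a higher number a weaker inhibitor), compound 1 `Cn1cccc1-c1nc2cc(NC(=O)CCCl)ccc2[nH]1` gives only a limit of the assay, > 50000 nM. Compound 2 `Cc1ccc(-c2nc3cc(NC(=O)CCCl)ccc3[nH]2)cc1` likewise gives only a limit, > 50000 nM. Between them lies a step that the two limits leave unreadable from compound 1 to compound 2. For the measured compounds named here, compound 3 `CCN1CCN(CCC(=O)Nc2ccc3[nH]c(-c4ccc(C)cc4)nc3c2)CC1` gives 14600 nM, so that an at least 3.4-fold lower number from compound 2 to compound 3 (0.53 log units; beyond the scatter) is the one readable change in the set. Going by the values given here, compound 2 therefore stands at the limit of > 50000 nM in this assay, at which 2 of the 3 values shown sit, alongside compound 1, with compound 3 as the only numbered value.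

Compound 4 `Cc1ccc(-c2nc3cc(NC(=O)CCN4CCN(C)CC4)ccc3[nH]2)cc1` has not been measured. It differs from compound 2 by 4-methylpiperazin-1-yl in place of chloro on a saturated chain carbon, two bonds along the chain from a carbonyl carbon. The step from compound 2 to compound 3 bears on this directly, since both changes put a piperazinyl substituent in place of chloro at the same place on the chain. A step of about the same size is expected in this assay, towards a lower number: an at least 3.3-fold lower number from compound 2 to compound 4 (0.52 log units; beyond the scatter). Compound 4 is estimated at 15000 nM, within a range from 6000 nM to 40000 nM.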

Compound 4, half-maximal inhibitory concentration: > 50000 nM
Compound 4 was reported as a limit; the forecaster's own chance of this, stated with the estimate: 25%; middle value at least 3.3-fold (0.52 log units) from the limit.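

In this assay, 4-methylpiperazin-1-yl in place of 4-ethylpiperazin-1-yl gives an at least 3.4-fold higher number from compound 3 to compound 4 (0.53 log units; beyond the scatter), so a piperazinyl group at this chain carbon does not by itself bring a reading under the limit, and the small alkyl group at the far end of that ring decides the result here. Compound 4 gives only a limit of the assay, as does compound 2, and the step between them cannot be read. Among the chloro and piperazinyl compounds, only compound 3 departs from the limit, and compound 4 goes against any general gain from replacing chloro: the limit of > 50000 nM in this assay, at which 3 of the 4 values shown sit.

From the compounds shown here alone, whether a 4-propylpiperazin-1-yl group at this chain carbon would lower the number further stays open. So does how a morpholin-4-yl group there would read, or a piperazinyl chain paired with the 1-methyl-1H-pyrrol-2-yl ring of compound 1.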